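From 4-chlorophenyl to 3-chlorophenyl on compound 1

A few compounds are considered here, and "the series" means these few. Any claim that something is new, unique, unknown or untested is made for them only; others in the source may bear on it.

Compound 1 (`COc1cc(-n2ncnc2-c2ccc(Cl)cc2)cc(OC)c1OC`) gives > 10000 nM in a functional assay on MCF7 cells (Homo sapiens) for antiproliferative activity, read by MTT assay, with a stated time of 72 h (on this read-out higher numbers stand for weaker inhibition and lower numbers for stronger inhibition), and this is a limit, not a number. Compound 2 (`COc1cc(-n2ncnc2-c2ccc(OC(F)(F)F)cc2)cc(OC)c1OC`) gives > 10000 nM in this assay and this too is a limit. Compound 1 thus sits at the limit of > 10000 nM in this assay, at which 2 of the 3 values shown sit, and has no exact place on the scale. Compound 3 (`CCOc1ccc(-c2ncnn2-c2cc(OC)c(OC)c(OC)c2)cc1`) gives 50 nM in this assay as a true number.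

Compound 4 (`COc1cc(-n2ncnc2-c2cccc(Cl)c2)cc(OC)c1OC`) differs from compound 1 by one change (3-chlorophenyl in place of 4-chlorophenyl on an aromatic carbon) and keeps the same atoms. For the measured compounds named here, no measured step moves the chlorine, so the evidence is indirect. Ethoxy in place of chloro gives an at least 200-fold lower number from compound 1 to compound 3 (2.30 log units; beyond the scatter) and is large. Ethyl in place of trifluoromethyl on the oxygen gives an at least 200-fold lower number from compound 2 to compound 3 (2.30 log units; beyond the scatter) and is equally large. Trifluoromethoxy in place of chloro gives a step that the two limits leave unreadable from compound 1 to compound 2 and shows nothing.

Compound 4 has no ethoxy group, so the expected result is no step beyond the scatter in this assay and most likely another limit. The estimated change is a number no higher from compound 1 to compound 4 (the limit leaves the size open) in this direction-free reading. For compound 4 the estimate is 10000 nM as an expected value, with an expected range from 2000 nM to 30000 nM in this assay overall.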

Compound 4, half-maximal inhibitory concentration: > 10000 nM
Compound 4: no number, only a limit; the forecaster's own chance of this, stated with the estimate: 60%; the middle value lies on the limit itself.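

In this assay compound 4 gives > 10000 nM, which is a limit and not a number. Compound 1 also stands at a limit, so no step between compound 1 and compound 4 can be read: the limit of > 10000 nM in this assay, at which 3 of the 4 values shown sit.

The compounds shown leave open whether 3-chlorophenyl and 4-chlorophenyl differ at all in this assay.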